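Swapping the phenylethyl arm for a tert-butyl ester

The compounds below may be only part of what the source reports. "The series", "measured", "known", "first", "only" and "open" are said of these compounds alone.

Three compounds share one core and differ only in the group on one amide nitrogen. Compound 1 `Cc1ccc(CNC(=O)c2[nH]cnc2C(=O)Nc2ccc(Cl)c(Cl)c2)cc1` carries a 4-methylbenzyl there; in a functional assay on HL-60 cells (Homo sapiens), with a stated time of 4 days (a lower number here means a stronger inhibitor, a higher number a weaker inhibitor), compound 1 gives 15200 nM. Compound 2 `C[C@@H](NC(=O)c1[nH]cnc1C(=O)Nc1ccc(Cl)c(Cl)c1)c1ccccc1` and compound 3 `C[C@H](NC(=O)c1[nH]cnc1C(=O)Nc1ccc(Cl)c(Cl)c1)c1ccccc1` carry a 1-phenylethyl instead, and in this assay compound 2 gives 5900 nM while compound 3 gives 5900 nM. The change produced a 2.6-fold lower number from compound 1 to compound 2 (0.41 log units; beyond the scatter) and a 2.6-fold lower number from compound 1 to compound 3 (0.41 log units; beyond the scatter). Compound 2 and compound 3 are mirror images at that chain carbon, and no change at the digits printed from compound 2 to compound 3 (within the scatter), which fits with the fact that compounds 2 and 3 differ only in the configuration as drawn. Compound 3 thus stands level with compound 2 at the lowest numbers of the three.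

Compound 4 `CC(C)(C)OC(=O)CNC(=O)c1[nH]cnc1C(=O)Nc1ccc(Cl)c(Cl)c1` changes the same position again: (tert-butoxycarbonyl)methyl in place of 1-phenylethyl on an amide-type nitrogen. The measured steps all concern swapping one aromatic-ring-bearing group for another or flipping configuration, and none of them removes the ring or brings in an ester, so they only loosely guide this step. A modest drift toward a higher number seems the more likely outcome, and compound 4 is expected to show a 2.5-fold higher number from compound 3 to compound 4 (0.41 log units; beyond the scatter) in this assay, with an estimated value of 15000 nM and a range from 4000 nM to 60000 nM.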

Compound 4, half-maximal inhibitory concentration: 25400 nM
For compound 4 the middle estimate is 1.7-fold (0.23 log units) below the measured one, and the stated range covers the measured number.
By their numbers in this assay, from the lowest: compounds 2 and 3 (each within the scatter of the next); then compounds 1 and 4 (each within the scatter of the next).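

Going by these compounds alone, replacing 1-phenylethyl with (tert-butoxycarbonyl)methyl is the first change here that removes the aromatic ring from this amide-type nitrogen, and in this assay the number rises by the same amount from either mirror image (a 4.3-fold higher number from compound 3 to compound 4 (0.63 log units; beyond the scatter)) and (a 4.3-fold higher number from compound 2 to compound 4 (0.63 log units; beyond the scatter)). Set against the 4-methylbenzyl group, the ester arm cannot be told apart (a 1.7-fold higher number from compound 1 to compound 4 (0.22 log units; within the scatter)), so an aromatic ring on this arm does not by itself give the lower numbers: compound 1 has such a ring yet sits level with ring-free compound 4, and among these arms only 1-phenylethyl stands apart. Nothing at hand gives a cause for these steps, since the only supporting fact concerns the mirror-image pair and not the ester.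

The change to compound 4 removes the ring and brings in an ester at once, so the compounds shown cannot say which of the two goes with the higher number. A carboxylic acid in place of the tert-butyl ester, or a plain hexyl chain with no ester and no ring, would pull those two changes apart at this position.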